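A larger group on a well-tolerated compound

The compounds below may be only part of what the source reports. "The series", "measured", "known", "first", "only" and "open" are said of these compounds alone.

Compound 1 `CCC(C)n1nc(-c2cccs2)c(O)c(C2=NS(=O)(=O)c3cc(NS(C)(=O)=O)ccc3N2)c1=O`: > 33000 nM
Compound 2 `CS(=O)(=O)Nc1ccc2c(c1)S(=O)(=O)N=C(c1c(O)c(-c3cccs3)nn(CC3CC3)c1=O)N2`: > 1000 nM

In an ADME assay on Huh-7 cells (Homo sapiens) for cytotoxicity, with a stated time of 72 h (a higher number here means that more compound is tolerated, a lower number that less compound is tolerated), compound 2 gives > 1000 nM, which is a limit and not a number. Compound 1 gives > 33000 nM, and this too is a limit. Among the measured compounds shown here, compound 2 therefore has no exact value to start from, and neither does its only neighbour.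

Compound 3 `CS(=O)(=O)Nc1ccc2c(c1)S(=O)(=O)N=C(c1c(O)c(-c3cccs3)nn(Cc3ccc(F)cc3)c1=O)N2` keeps the shared core and changes one group: 4-fluorophenyl in place of cyclopropyl on a saturated chain carbon bound to an aromatic nitrogen. In words, this is 4-fluorophenyl in place of cyclopropyl on a saturated chain carbon bound to an aromatic nitrogen.

For the measured compounds named here, the one measured step at this place is a step that the two limits leave unreadable from compound 1 to compound 2. It offers neither a size nor a direction to carry over, so no clear step is expected in this assay. The expected value for compound 3 is 15000 nM, with an estimated range from 2500 nM to 50000 nM. The estimated step is a step that the limit leaves unreadable from compound 2 to compound 3.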

Compound 3, half-maximal cytotoxic concentration: > 1000 nM
Compound 3 was reported as a limit; the forecaster's own chance of this, stated with the estimate: 80%; the middle value is on the limit's open side.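

No new step can be read from compound 3: like compound 1 and compound 2, it is reported only as a limit, so neither size nor direction can be told among the three. On these data alone, how far the sec-butyl, cyclopropylmethyl and 4-fluorobenzyl compounds truly differ in tolerated concentration stays open.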